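Replacing a Nitrile by Chlorine on a Receptor Agonist

The source may hold more compounds than are shown below. What is called first, only, known or untested is meant among the compounds shown, and "the series" means these compounds.

Of the compounds shown here, three have been tested in a functional assay on CHO cells for agonist activity at metabotropic glutamate receptor 2 (Homo sapiens); a lower number here means a smaller maximal response, a higher number a larger maximal response. Compound 1 `FC(F)(F)Cc1cnc2c(Cl)c(-c3cc(Cl)c4c(ccn4CC4CC4)c3)ccn12` gives 193%. Compound 2 `N#Cc1c(-c2cc(Cl)c3[nH]ccc3c2)ccn2c(CC(F)(F)F)cnc12` gives 277%. Compound 3 `N#Cc1c(-c2cc(Cl)c3c(ccn3CC3CC3)c2)ccn2c(CC(F)(F)F)cnc12` gives 200%. Among these three, compound 2 stands highest: its nearest neighbour is compound 3, and the step of a number 77 percentage points lower from compound 2 to compound 3 (beyond the scatter) is large, while the gap to compound 1 is wider still.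

Compound 4 `FC(F)(F)Cc1cnc2c(Cl)c(-c3cc(Cl)c4[nH]ccc4c3)ccn12` has not yet been measured. It differs from compound 2 in one place: chloro in place of cyano on an aromatic carbon. The same exchange, run the other way, is already on record: a number 7 percentage points higher from compound 1 to compound 3 (within the scatter), which is a change too small to count. For the measured compounds named here, that step connects two compounds that both carry the cyclopropylmethyl group, whereas compound 2 and compound 4 carry hydrogen on the aromatic nitrogen, so the comparison is not exact, but it is the only guide available.

The expectation is therefore a step of no more than the usual scatter, in either direction. On that basis compound 4 is estimated to give 270% in this assay, with a range from 230% to 310%. The expected step of a number 7 percentage points lower from compound 2 to compound 4 (within the scatter) is accordingly small.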

Compound 4, largest response reached (Emax), in percent of the reference or control that the assay uses: 217%
Estimate against measurement, compound 4: 53 percentage points above; measured number outside the range, below it.
By their numbers in this assay, from the lowest: compounds 1 and 3 (each within the scatter of the next); then compound 4; then compound 2.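

The new compound shows that the exchange at this aromatic carbon is not neutral in every setting: in this assay, putting chloro in place of cyano gives a number 60 percentage points lower from compound 2 to compound 4 (beyond the scatter). What the group on this carbon does therefore depends on what sits on the aromatic nitrogen, and across these four compounds the two places do not act independently: the same change on two cores in this assay, a number 7 percentage points higher (within the scatter) from compound 1 to compound 3 and a number 60 percentage points higher (beyond the scatter) from compound 4 to compound 2, 53 percentage points apart, beyond the scatter of two such steps. Read from the other place, hydrogen in place of cyclopropylmethyl gives a number 24 percentage points higher from compound 1 to compound 4 (beyond the scatter), so the gain from removing that group is also tied to the group on the aromatic carbon, being smaller with chloro than with cyano: the same change on two cores in this assay, a number 77 percentage points lower (beyond the scatter) from compound 2 to compound 3 and a number 24 percentage points lower (beyond the scatter) from compound 4 to compound 1, 53 percentage points apart, beyond the scatter of two such steps.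

For the compounds shown here, these four compounds show that the two places are linked but give no reason for the link, and they cover only two groups at each place. From the compounds shown here alone, how a methyl or methoxy group on the aromatic carbon, or a longer chain such as n-propyl on the aromatic nitrogen, would fit this picture stays open.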